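Sulfonyl Aryl Swap on a Quinoline Core: Compound 3 Ahead

The source may report more compounds than this note shows. Statements on the series, on what has been measured and on what is new or still open speak of the compounds shown alone.

Compound 1 `O=S(=O)(c1ccc(F)c(F)c1)c1cnc2c(F)cccc2c1-c1ccc(Cl)cc1`; in a functional assay on the whole organism (strain Wistar) with Rattus norvegicus as the target (on this read-out higher numbers stand for an effect only at larger amounts of compound and lower numbers for an effect already at smaller amounts), compound 1 gives 3 mg/kg.
Compound 2 `O=S(=O)(c1cc(Cl)cc(Cl)c1)c1cnc2c(F)cccc2c1-c1ccc(F)cc1`; in this assay compound 2 gives 30 mg/kg.

Among the measured compounds shown here, of the two numbers measured so far, compound 2 holds the highest; its nearest neighbour is compound 1, and the gap between them lies beyond the usual scatter. The next compound, compound 3 `O=S(=O)(c1cccc(F)c1)c1cnc2c(F)cccc2c1-c1ccc(F)cc1`, has not yet been measured. Compound 3 differs from compound 2 in one place (3-fluorophenyl in place of 3,5-dichlorophenyl on a sulfonyl sulfur). For the measured compounds named here, no step between measured compounds is known for this change, so the direction can only be guessed from where compound 1 stands with a fluorinated group on the sulfonyl sulfur. A downward step is expected from compound 2 to compound 3 of a 3.0-fold lower number from compound 2 to compound 3 (0.48 log units; beyond the scatter). For compound 3 the estimated result in this assay is 10 mg/kg, with a range from 3 mg/kg to 30 mg/kg.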

Compound 3, minimum effective dose: 30 mg/kg
Beside the measured number, compound 3's estimate is 3.0-fold (0.48 log units) below it; the measured number falls inside the stated range.
By their numbers in this assay, from the lowest: compound 1; then compounds 2 and 3 (each within the scatter of the next).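

In this assay, 3-fluorophenyl in place of 3,5-dichlorophenyl on a sulfonyl sulfur gives no change at the digits printed from compound 2 to compound 3 (within the scatter). This is the only single-place step at this position among the compounds shown, and it reveals that the read-out does not separate these two aryl groups, even though one carries two chlorine atoms and the other a single fluorine. The data offer no explanation for this flat result.

Among the compounds shown here, compound 1 differs from compound 2 and from compound 3 in more than one place, so no step to it can be read, and what sets its number apart remains open. Also open, as far as these compounds go, is whether anything other than a halogenated phenyl on the sulfonyl sulfur, such as a piperidine or a phenyl bearing a carboxylic acid, would move the number in this whole-animal read-out.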